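The source may hold more compounds than are shown below. What is called first, only, known or untested is meant among the compounds shown, and "the series" means these compounds.

Compound 1 `CCOC(=O)c1c(-c2cccc(OCC)c2)[nH]c2cc(OC)ccc2c1=O` in an ADME assay on BJ cells (Homo sapiens) for cytotoxicity, read by luminescence, with a stated time of 72 h (on this read-out higher numbers stand for an effect only at larger amounts of compound and lower numbers for an effect already at smaller amounts), gives > 21500 nM, which is a limit and not a number.
Compound 2 `CCOC(=O)c1c(-c2cccc(OCC(C)C)c2)[nH]c2cc(OC)ccc2c1=O` in this assay gives > 21500 nM, likewise a limit.
Compound 3 `CCOC(=O)c1c(-c2cccc(OCc3ccccc3)c2)[nH]c2cc(OC)ccc2c1=O` in this assay gives > 21500 nM, again a limit.

Compound 3 therefore stands where every measured value stands, at the edge of what this assay reports, since (the limit of > 21500 nM in this assay, at which 3 of the 3 values shown sit). The three steps among the measured compounds, a step that the two limits leave unreadable from compound 1 to compound 2, a step that the two limits leave unreadable from compound 1 to compound 3 and a step that the two limits leave unreadable from compound 2 to compound 3, are all unreadable in size and direction, as each connects two limits. The change from compound 3 to compound 4 `CCOC(=O)c1c(-c2cccc(O)c2)[nH]c2cc(OC)ccc2c1=O` is hydrogen in place of benzyl on an oxygen on an aromatic ring. The steps from compound 1 to compound 3 and from compound 2 to compound 3 alter the group on the same oxygen and are the ones that bear on this change, but they give no readable size. Within the data shown here, no measured step points to a shift beyond the scatter, and compound 4 is expected to remain at the limit, the step that the limit leaves unreadable from compound 3 to compound 4 being only a formal one. Compound 4 is estimated at 30000 nM, with a range from 15000 nM to 100000 nM.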

Compound 4, half-maximal effective concentration: > 21500 nM
Compound 4: a limit, no number (the forecaster's own chance of this, stated with the estimate: 85%); the middle value is on the limit's open side.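

Compound 4 also gives only a limit, so the steps linking compound 1, compound 2 and compound 3 to compound 4 cannot be read in size or direction: the limit of > 21500 nM in this assay, at which 4 of the 4 values shown sit. The compounds shown leave open at what concentration any of them would reach a half-maximal effect in this assay.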